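A few compounds are considered here, and "the series" means these few. Any claim that something is new, unique, unknown or untested is made for them only; others in the source may bear on it.

Compound 1 `COc1ccc(Cc2nnc(NC(=O)/C(C#N)=C/c3ccccc3OS(=O)(=O)c3ccc(OC)cc3)s2)cc1` - 78%
Compound 2 `COc1ccc(S(=O)(=O)Oc2ccccc2/C=C(\C#N)C(=O)Nc2nnc(Cc3cccc4ccccc34)s2)cc1` - 78%
Compound 3 `N#C/C(=C\c1ccccc1OS(=O)(=O)c1ccc([N+](=O)[O-])cc1)C(=O)Nc1nnc(Cc2cccc3ccccc23)s1` - 58%

In a functional assay on RS4-11 cells (Homo sapiens) for inhibition, read by CCK-8 assay, with a stated time of 48 h, tested at 20 uM (a lower number here means less inhibition of growth, a higher number more inhibition of growth at the concentration tested), compound 2 gives 78%, the same number as compound 1 and the top of the three. Compound 4 `COc1ccc(S(=O)(=O)Oc2ccccc2/C=C(\C#N)C(=O)Nc2nnc(Cc3ccccc3)s2)cc1` has not yet been measured. It differs from compound 2 by one group phenyl in place of naphthalen-1-yl on a saturated chain carbon bound to an aromatic carbon.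

The closest evidence comes from that same place, where naphthalen-1-yl in place of 4-methoxyphenyl gave no change at the digits printed from compound 1 to compound 2 (within the scatter). The other measured change, nitro in place of methoxy, gave a number 20 percentage points lower from compound 2 to compound 3 (beyond the scatter), but it concerns a different place and says little here. Going by the values given here, no measured compound carries the plain phenyl, so the expectation remains uncertain. In this assay the expected outcome is a small drop at most, within the scatter: a number 4 percentage points lower from compound 2 to compound 4 (within the scatter). For compound 4 the estimated value is 74%, with an expected range of 60% to 88%.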

Compound 4, percent growth inhibition at one concentration: 78%
Compound 4: the middle estimate sits 4 percentage points below what was measured; the range from low to high includes it.
By their numbers in this assay, from the lowest: compound 3; then compounds 1, 2 and 4 (each within the scatter of the next).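

Replacing naphthalen-1-yl with phenyl gives no change at the digits printed from compound 2 to compound 4 (within the scatter) in this assay, so at this place on the saturated chain carbon the second aromatic ring of the naphthalen-1-yl brings no visible gain in growth inhibition. Removing the methoxy from the 4-methoxyphenyl group gives no change at the digits printed from compound 1 to compound 4 (within the scatter), so phenyl, 4-methoxyphenyl and naphthalen-1-yl cannot be told apart here at the single concentration tested. Nothing among the data shown explains why these groups read alike.

On these data alone, whether this place needs an aromatic ring at all remains open, as a cyclohexyl group or a plain methyl would show. As far as these compounds go, it is also open whether a charged group, such as an amine or a carboxylic acid on the phenyl ring, would be tolerated as well as the methoxy.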